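Trading an Ethylphenyl Tail for a Phenoxy Group

The source may hold more compounds than are shown below. What is called first, only, known or untested is meant among the compounds shown, and "the series" means these compounds.

Compound 1 `CCc1ccc(-c2ccc(NC3=CC(=O)c4ncncc4C3=O)cc2)cc1` carries a 4-ethylphenyl group on the shared core. Going by the values given here, in a functional assay on MIA PaCa-2 cells (Homo sapiens) for cytotoxicity, read by MTT assay, with a stated time of 72 h (on this read-out lower numbers stand for stronger inhibition and higher numbers for weaker inhibition), compound 1 gives 2000 nM, the lowest of the three numbers measured so far. Compound 3 `CC(=O)c1cccc(NC2=CC(=O)c3ncncc3C2=O)c1` gives 2300 nM, a value within the scatter of compound 1, so the two cannot be ranked against each other. The bare core, compound 2 `O=C1C=CC(=O)c2ncncc21`, gives 9400 nM, a gap beyond the scatter from compound 1. Compound 4 `O=C1C(Nc2ccc(Oc3ccccc3)cc2)=CC(=O)c2ncncc21` has not yet been measured; it differs from compound 1 by phenoxy in place of 4-ethylphenyl on an aromatic carbon. Since both groups are one six-membered aromatic ring of carbon only, the step of a 1.3-fold higher number from compound 1 to compound 4 (0.10 log units; within the scatter) is expected to stay within the usual scatter. Compound 4 is therefore estimated to give 2500 nM, with a likely range from 1000 nM to 6000 nM.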

Compound 4, half-maximal inhibitory concentration: 3700 nM
Compound 4: the middle estimate sits 1.5-fold (0.17 log units) below what was measured; the range from low to high includes it.
By their numbers in this assay, from the lowest: compounds 1, 3 and 4 (each within the scatter of the next); then compound 2.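

In this assay, phenoxy in place of 4-ethylphenyl gives a 1.9-fold higher number from compound 1 to compound 4 (0.27 log units; within the scatter), so the two compounds cannot be told apart. At this place on the aromatic ring, the read-out therefore stays unchanged when an oxygen and a hydrogen-bond acceptor enter with the phenoxy group. Nothing shown explains why these two groups read alike.

Going by these compounds, it remains open how an amine, a carboxylic acid or a longer chain would read in this place. On these data alone, it is also open whether a group without an aromatic ring would hold the number.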